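The source may hold more compounds than are shown below. What is called first, only, known or untested is meant among the compounds shown, and "the series" means these compounds.

Compound 1 `COc1cccc(F)c1CNC(=O)c1[nH]c2ccc(Cl)cc2c1S(=O)(=O)c1cc(C)cc(C)c1` gives > 49900 nM in an ADME assay on MT4 cells (Homo sapiens) for cytotoxicity, read by MTT assay (a higher number here means that more compound is tolerated, a lower number that less compound is tolerated), which is a limit.
Compound 2 `Cc1cc(C)cc(S(=O)(=O)c2c(C(=O)NC(C)c3ccccc3F)[nH]c3ccc(Cl)cc23)c1` gives > 51500 nM in this assay, again a limit.
Compound 3 `Cc1cc(C)cc(S(=O)(=O)c2c(C(=O)NCC(=O)NCc3ccncn3)[nH]c3ccc(Cl)cc23)c1` gives > 48800 nM in this assay, also a limit.

Compound 1 therefore stands at a limit in this assay, and the two other values shown are limits as well. Compound 4 `Cc1cc(C)cc(S(=O)(=O)c2c(C(=O)NC(C)C(=O)NCc3ccncn3)[nH]c3ccc(Cl)cc23)c1` differs from compound 1 by a group of 12 heavy atoms (8 carbon, 3 nitrogen, 1 oxygen; one six-membered aromatic ring with 2 hetero atoms) in place of a group of 10 heavy atoms (8 carbon, 1 oxygen, 1 fluorine; one six-membered aromatic ring of carbon only), on an amide-type nitrogen. Going by the values given here, the steps that bear on this change are a step that the two limits leave unreadable from compound 1 to compound 2 and a step that the two limits leave unreadable from compound 1 to compound 3; because of the limit of > 48800 nM in this assay, at which 1 of the 3 values shown sits, the limit of > 49900 nM in this assay, at which 1 of the 3 values shown sits, and the limit of > 51500 nM in this assay, at which 1 of the 3 values shown sits, each hold one of the values, no size can be read from either step, and no step beyond the scatter is expected in this assay in either direction. Compound 4 is therefore expected to give about 50000 nM, between 30000 nM and 100000 nM, most likely again reported as a limit. The expected step is a step that the limit leaves unreadable from compound 1 to compound 4.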

Compound 4, half-maximal cytotoxic concentration: 28100 nM
The estimate for compound 4 lay 1.8-fold (0.25 log units) above the measured number; the measured number lies below the stated range.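

Going by these compounds alone, compound 4 is the first compound here to give a number rather than a limit in this assay. Methyl in place of hydrogen on the saturated chain carbon gives an at least 1.7-fold lower number from compound 3 to compound 4 (0.23 log units; that floor lies within the scatter), and the larger changes on the amide-type nitrogen give an at least 1.7-fold lower number from compound 1 to compound 4 (0.24 log units; that floor lies within the scatter) and an at least 1.8-fold lower number from compound 2 to compound 4 (0.26 log units; that floor lies within the scatter). Each is only a floor within the scatter, the one from compound 3 because compound 3 holds a limit: the limit of > 48800 nM in this assay, at which 1 of the 4 values shown sits.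

As far as these compounds go, the steps among compounds 1, 2 and 3 still cannot be read, and the true size of the new steps stays open. Also open, from the compounds shown here alone, is what an ethyl group on that saturated chain carbon would give in this assay.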